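A Piperidine in Place of the Acetamido Chain

A few compounds are considered here, and "the series" means these few. Any claim that something is new, unique, unknown or untested is made for them only; others in the source may bear on it.

Compound 1, `CC(C)CCCN(C(=O)[C@@H]1C[C@H]1c1ccccc1)c1ccc(-c2ccccc2)cc1`, gives > 100 nM in a functional assay for agonist activity at G protein-coupled receptor 88 (Homo sapiens), read by HTRF and cAMP accumulation; on this read-out lower numbers stand for an effect already at smaller amounts and higher numbers for an effect only at larger amounts of compound.
Compound 2, `CC[C@H](C)[C@@H](CN(C(=O)[C@@H]1C[C@H]1c1ccccc1)c1ccc(-c2ccccc2)cc1)NC(C)=O`, gives 5.8 nM in this assay.

Going by the values given here, compound 2 holds the only number among the two values; the value of compound 1 is a limit of the assay and not a number (the limit of > 100 nM in this assay, at which 1 of the 2 values shown sits). Among the compounds with values here, the one measured step, an at least 17-fold lower number from compound 1 to compound 2 (1.23 log units; beyond the scatter), exchanged isopentyl for 1-acetamido-2-methylbutyl. Compound 3, `O=C([C@@H]1C[C@H]1c1ccccc1)N(CC1CCCNC1)c1ccc(-c2ccccc2)cc1`, turns this around in part: piperidin-3-yl in place of 1-acetamido-2-methylbutyl on a saturated chain carbon bound to an amide-type nitrogen. The earlier step bears directly, since the group that then entered now leaves, while piperidin-3-yl brings its own donor and acceptor. A step towards higher numbers, smaller than that earlier one but beyond the scatter, is therefore expected, a 6.9-fold higher number from compound 2 to compound 3 (0.84 log units; beyond the scatter). In this assay compound 3 is estimated at 40 nM, with a range from 8 nM to 200 nM.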

Compound 3, half-maximal effective concentration: 10 nM
Compound 3: the middle estimate sits 4.0-fold (0.60 log units) above what was measured; low and high end bracket the measured number.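

The exchange of 1-acetamido-2-methylbutyl for piperidin-3-yl gives a 1.7-fold higher number from compound 2 to compound 3 (0.24 log units; within the scatter), so compound 2 and compound 3 cannot be told apart in this assay, and the open acetamido chain with its defined stereocentres is not needed at this place for a value in this range. Set against the isopentyl group, the ring gives an at least 10-fold lower number from compound 1 to compound 3 (1.00 log units; beyond the scatter), so a second, quite different group now separates from isopentyl on a saturated chain carbon bound to an amide-type nitrogen. The value of compound 1 is a limit of the assay and not a number: the limit of > 100 nM in this assay, at which 1 of the 3 values shown sits.

The compounds shown leave open whether the ring nitrogen of piperidin-3-yl matters, which a cyclohexyl group in its place would address. Also open, as far as these compounds go, is how an acetyl group on that ring nitrogen would read, joining the ring to the amide of compound 2.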